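This account rests on a few compounds, and the source may have more. Where it says the series, first, only, none or still open, it means among the compounds named here.

Measured so far:

Compound 1, `CC1C/C(=N\Nc2ccccc2)c2ncc(C(=O)O)c(=O)n2C1`: 5.7 umol/kg
Compound 2, `CC1CC/C(=N\Nc2ccc(F)cc2)c2ncc(C(=O)O)c(=O)n21`: 12.2 umol/kg

Two compounds have been run in a functional assay on the whole organism for inhibition, with Rattus norvegicus as the target; on this read-out higher numbers stand for an effect only at larger amounts of compound and lower numbers for an effect already at smaller amounts. Compound 1 gives 5.7 umol/kg in this assay, whereas compound 2 gives 12.2 umol/kg. Compound 2 therefore holds the higher of the two numbers; the gap to compound 1 lies beyond the usual scatter of repeated measurements, so compound 1 shows its effect at the smaller amount of the two. The two compounds also differ in more than one place, so no single structural step can be read from that pair.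

Compound 3, `CC1CC/C(=N\Nc2ccc(Cl)cc2)c2ncc(C(=O)O)c(=O)n21`, has not yet been measured in this assay. It differs from compound 2 in one place: chloro in place of fluoro on an aromatic carbon. Going by the values given here, no measured pair in this set shows the effect of such an exchange, so nothing in the data supports a direction. On that basis the change from compound 2 to compound 3 is expected to be small, a 1.2-fold lower number from compound 2 to compound 3 (0.09 log units; within the scatter), and not beyond the scatter. Compound 3 is accordingly estimated to give 10 umol/kg in this assay, within a range of 4 umol/kg to 30 umol/kg.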

Compound 3, dose for 50% inhibition: 0.5 umol/kg
Beside the measured number, compound 3's estimate is 20-fold (1.30 log units) above it; measured number outside the range, below it.
By their numbers in this assay, from the lowest: compound 3; then compound 1; then compound 2.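

The exchange of fluoro for chloro on an aromatic carbon, para to a large group, gives a 24-fold lower number from compound 2 to compound 3 (1.39 log units; beyond the scatter) in this assay, so this place on the ring is sensitive to the identity of its substituent. The change is small on paper, one heavy atom for one heavy atom, with no ring, hydrogen-bond donor, hydrogen-bond acceptor or net charge entering or leaving, yet the step is large and lies beyond the scatter, which the earlier pair could not show, as its two compounds differ in more than one place. Nothing available explains why this single exchange has so large an effect on the read-out.

The compounds shown leave open whether chloro is a special case at this place or whether other groups, such as bromo, methyl or methoxy, would give numbers as low as that of compound 3 or lower still. They also leave open whether the same exchange would carry a comparable step on the core of compound 1, and what a plain unsubstituted phenyl would give on the core shared by compound 2 and compound 3.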